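The source may hold more compounds than are shown below. What is called first, only, known or untested is meant among the compounds shown, and "the series" means these compounds.

Compound 2 `ClCc1ccccc1Cn1cnc2c(Cl)nc(Cl)nc21` shares its purine-like core with compound 3 `Nc1nc(Cl)c2ncn(Cc3ccc(CCl)cc3)c2n1` and compound 1 `ClCc1ccc(Cn2cnc3c(Cl)ncnc32)cc1`, for which a functional assay on SW-620 cells (Homo sapiens) for cytotoxicity, read by sulforhodamine B assay, with a stated time of 48 h (on this read-out higher numbers stand for weaker inhibition of growth and lower numbers for stronger inhibition of growth), records "not determined" (no result reported). In this assay compound 2 gives 150 nM, the lowest of the two numbers reported, while compound 3 gives 3390 nM, a gap beyond the usual scatter. Compound 4 `Nc1nc(Cl)c2ncn(Cc3ccccc3CCl)c2n1` differs from compound 2 in one place: amino in place of chloro on an aromatic carbon. Within the data shown here, no measured pair shows this swap on its own, so its effect is uncertain; since compound 3, which carries the same amino group, gives 3390 nM, the expected step from compound 2 to compound 4 is a weakening, a 10-fold higher number from compound 2 to compound 4 (1.00 log units; beyond the scatter). Compound 4 is therefore estimated at 1500 nM, plausibly between 300 nM and 8000 nM.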

Compound 4, concentration for 50% growth inhibition: 3310 nM
The estimate for compound 4 lay 2.2-fold (0.34 log units) below the measured number, within the range that was stated.
By their numbers in this assay, from the lowest: compound 2; then compounds 4 and 3 (each within the scatter of the next).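

Measured directly, amino in place of chloro on this aromatic carbon, between two ring nitrogen atoms, gives in this assay a 22-fold higher number from compound 2 to compound 4 (1.34 log units; beyond the scatter). Among these compounds, at this position, then, the chloro group goes with much stronger inhibition of growth than the amino group, a change that the earlier compounds could not show on its own. No available evidence explains the size of this loss.

As far as these compounds go, it remains open whether a methoxy group or a methylamino group on this carbon would give a number closer to that of compound 2 or that of compound 4.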